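The source may report more compounds than this note shows. Statements on the series, on what has been measured and on what is new or still open speak of the compounds shown alone.

Measured in a functional assay on HCT-15 cells (Homo sapiens) for antiproliferative activity, read by sulforhodamine B assay, with a stated time of 48 h; a higher number here means a weaker inhibitor, a lower number a stronger inhibitor:
- compound 1 `C/C=C(\C)C(=O)O[C@H]1C=CC(=O)O[C@H]1CCC(=O)[C@H](C)O`: 18000 nM
- compound 2 `C/C=C(\C)C(=O)O[C@H]1C=CC(=O)O[C@H]1COC(=O)[C@H](C)O`: 11000 nM

In this assay, within the data shown here, compound 2 gives 11000 nM, which cannot be told apart from the only other measured value. Compound 3 `C/C=C(\C)C(=O)O[C@H]1C=CC(=O)O[C@H]1CNC(=O)[C@H](C)O` has not yet been measured and differs from compound 2 as follows: ((1-hydroxyethyl)carbonyl)amino in place of ((1-hydroxyethyl)carbonyl)oxy on a saturated chain carbon bound to a saturated ring carbon. In words, ((1-hydroxyethyl)carbonyl)amino stands in place of ((1-hydroxyethyl)carbonyl)oxy on a saturated chain carbon bound to a saturated ring carbon. One measured step changes the group at this place: a 1.6-fold lower number from compound 1 to compound 2 (0.21 log units; within the scatter). A change of similar size is therefore expected, with no step beyond the scatter in either direction. The expected step is a 1.4-fold higher number from compound 2 to compound 3 (0.13 log units; within the scatter). For compound 3 the estimated value is 15000 nM, with an expected range from 6000 nM to 40000 nM.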

Compound 3, half-maximal inhibitory concentration: 25000 nM
For compound 3 the middle estimate is 1.7-fold (0.22 log units) below the measured one; measured number inside the range.
By their numbers in this assay, from the lowest: compounds 2, 1 and 3 (each within the scatter of the next, the first and the last beyond it).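

Swapping the ((1-hydroxyethyl)carbonyl)oxy group for ((1-hydroxyethyl)carbonyl)amino in this assay gives a 2.3-fold higher number from compound 2 to compound 3 (0.36 log units; beyond the scatter) and is the first step in this series to pass the scatter, though only modestly. The same amino group set against ((1-hydroxyethyl)carbonyl)methyl gives a 1.4-fold higher number from compound 1 to compound 3 (0.14 log units; within the scatter) and stays within the scatter, so only the change from the oxy group can be told apart here. Nothing available explains this difference. On these data alone, whether a free amine or a carboxylic acid on this saturated chain carbon would shift the number further remains open.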